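Sulfonyl in place of carbonyl on the aromatic-ring nitrogen

The compounds below may be only part of what the source reports. "The series", "measured", "known", "first", "only" and "open" are said of these compounds alone.

Going by the values given here, compound 1 `O=C(/C=C/c1cccc(NC(=O)c2ccccc2Br)c1)c1nc2ccccc2[nH]1` gives 4520 nM in a functional assay on MCF7 cells (Homo sapiens) for antiproliferative activity, read by MTT assay, with a stated time of 48 h (on this read-out higher numbers stand for weaker inhibition and lower numbers for stronger inhibition), the lowest of the two numbers so far; its nearest neighbour, compound 2 `COc1cccc(C(=O)Nc2cccc(/C=C/C(=O)c3nc4ccccc4[nH]3)c2)c1`, gives 17800 nM in this assay. Among the compounds with values here, the one measured step, a 3.9-fold higher number from compound 1 to compound 2 (0.60 log units; beyond the scatter), exchanges the phenyl group on the carbonyl carbon and keeps the carbonyl itself. Compound 3 `O=C(/C=C/c1cccc(NS(=O)(=O)c2ccccc2Cl)c1)c1nc2ccccc2[nH]1` differs from compound 1 by (2-chlorophenyl)sulfonyl in place of (2-bromophenyl)carbonyl on a nitrogen on an aromatic ring. Within the data shown here, no measured step touches the group that joins the phenyl ring to the nitrogen, so the step from compound 1 to compound 2 bears on the present change only by showing that this end of the shared core shifts modestly when varied. Among the measured compounds shown here, with no closer precedent, a step beyond the scatter is not expected in either direction in this assay, though a modest weakening is possible. Compound 3 is therefore estimated at 6500 nM, range 2200 nM to 20000 nM, an expected step of a 1.4-fold higher number from compound 1 to compound 3 (0.16 log units; within the scatter).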

Compound 3, half-maximal inhibitory concentration: 4280 nM
Estimate against measurement, compound 3: 1.5-fold (0.18 log units) above, and the stated range covers the measured number.
By their numbers in this assay, from the lowest: compounds 3 and 1 (each within the scatter of the next); then compound 2.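

In this assay, the nitrogen on an aromatic ring carries (2-chlorophenyl)sulfonyl in place of (2-bromophenyl)carbonyl with a 1.1-fold lower number from compound 1 to compound 3 (0.02 log units; within the scatter), so the two groups cannot be told apart at this position on this read-out. The (3-methoxyphenyl)carbonyl group stays apart from the sulfonyl group, with a 4.2-fold lower number from compound 2 to compound 3 (0.62 log units; beyond the scatter), which shows that a carbonyl on this nitrogen is not required for numbers at the level of compound 1. No supporting data accompany these numbers to explain them.

The change replaces the linking group and the halogen together, so the separate contributions of the sulfonyl and of the chlorine remain unresolved. Also open, from the compounds shown here alone, is how this position responds to a methylsulfonyl group or a longer alkyl chain in place of the substituted phenyl, or to a carboxylic acid on that phenyl ring.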